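Swapping a Furan for a Chloropyridine on the Thiazole Core

A few compounds are considered here, and "the series" means these few. Any claim that something is new, unique, unknown or untested is made for them only; others in the source may bear on it.

Three compounds share a core and differ only in the ring attached to one aromatic carbon. Compound 1 `O=C(O)Cc1sc(C(c2ccc(F)cc2)c2ccc(F)cc2)nc1-c1cc(F)cc(F)c1` in an in vitro assay on HEK385-7 cells for displacement of a labelled ligand from prostaglandin D2 receptor 2 (Homo sapiens) (a higher number here means a weaker inhibitor, a lower number a stronger inhibitor), gives 35 nM. Compound 2 `NS(=O)(=O)c1cccc(-c2nc(C(c3ccc(F)cc3)c3ccc(F)cc3)sc2CC(=O)O)c1` gives 140 nM in this assay. Compound 3 `O=C(O)Cc1sc(C(c2ccc(F)cc2)c2ccc(F)cc2)nc1-c1ccco1` gives 18 nM in this assay, the lowest of the three numbers; its nearest neighbour on the numbers is reached by a 1.9-fold lower number from compound 1 to compound 3 (0.29 log units; within the scatter), within the scatter, and its furthest by a 7.8-fold lower number from compound 2 to compound 3 (0.89 log units; beyond the scatter), beyond it. The two aryl replacements themselves differ by a 4.0-fold higher number from compound 1 to compound 2 (0.60 log units; beyond the scatter).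

Compound 4 `O=C(O)Cc1sc(C(c2ccc(F)cc2)c2ccc(F)cc2)nc1-c1ccnc(Cl)c1` carries the change (2-chloropyridin-4-yl in place of furan-2-yl on an aromatic carbon). Among the measured compounds shown here, the steps that bear on it are those that exchanged this same ring: the furan gave the lowest number, and the halogenated six-membered ring of compound 1 sat within the scatter of it, whereas the sulfamoyl ring of compound 2 lay beyond. For the measured compounds named here, the incoming ring resembles the one in compound 1 most, so a modest rise is expected, a 2.2-fold higher number from compound 3 to compound 4 (0.35 log units; beyond the scatter), because compound 1 gives 35 nM in this assay. Compound 4 is therefore estimated at 40 nM, with a range from 15 nM to 110 nM.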

Compound 4, half-maximal inhibitory concentration: 3.1 nM
Compound 4: the middle estimate sits 13-fold (1.11 log units) above what was measured; the measured number lies below the stated range.
By their numbers in this assay, from the lowest: compound 4; then compounds 3 and 1 (each within the scatter of the next); then compound 2.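

The 2-chloropyridin-4-yl ring stands apart from every other ring at this aromatic carbon in this assay, with a 5.8-fold lower number from compound 3 to compound 4 (0.76 log units; beyond the scatter) from the furan-2-yl ring, an 11-fold lower number from compound 1 to compound 4 (1.05 log units; beyond the scatter) from the 3,5-difluorophenyl ring and a 45-fold lower number from compound 2 to compound 4 (1.65 log units; beyond the scatter) from the 3-sulfamoylphenyl ring. The earlier compounds shown here showed the furan-2-yl and 3,5-difluorophenyl rings within the scatter of each other, whereas this result shows that the position can reach clearly lower numbers and that two six-membered halogen-bearing rings need not read alike here. No measured evidence is available to explain this gain.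

The compounds shown leave open whether the chlorine or the ring nitrogen goes with the lower number. Going by these compounds, it also remains open how a methyl, a methoxy group or an amine would read in place of that chlorine.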